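Four Ribonucleoside Analogues Tested for Growth Inhibition of Colon Cells

The source may report more compounds than this note shows. Statements on the series, on what has been measured and on what is new or still open speak of the compounds shown alone.

The study compares three measured compounds and one yet to be measured in a functional assay on HCT-116 cells (Homo sapiens), read by MTT assay, with a stated time of 72 h; on this read-out lower numbers stand for stronger inhibition and higher numbers for weaker inhibition. Compound 1 has the structure `COc1nc(N)nc2c1c(-c1ccccc1)cn2[C@@H]1O[C@H](CO)[C@@H](O)[C@H]1O`. In this assay compound 1 gives only a limit, > 20000 nM. Compound 2, `COc1nc(N)nc2c1c(-c1cccs1)cn2[C@@H]1O[C@H](CO)[C@@H](O)[C@H]1O`, differs from compound 1 by the change (thiophen-2-yl in place of phenyl on an aromatic carbon). In this assay compound 2 likewise gives only a limit, > 20000 nM. The step that the two limits leave unreadable from compound 1 to compound 2 therefore cannot be read, since both values sit at a limit. Compound 3, `Nc1nc(N)c2c(-c3ccccc3)cn([C@@H]3O[C@H](CO)[C@@H](O)[C@H]3O)c2n1`, has a different core: the difference is amino in place of methoxy on an aromatic carbon. In this assay compound 3 again gives only a limit, > 20000 nM. The step that the two limits leave unreadable from compound 1 to compound 3 is equally unreadable. All three measured values rest on the same footing, (the limit of > 20000 nM in this assay, at which 3 of the 3 values shown sit).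

Compound 4, `Nc1nc(N)c2c(-c3cccs3)cn([C@@H]3O[C@H](CO)[C@@H](O)[C@H]3O)c2n1`, is not yet measured. It differs from compound 3 by thiophen-2-yl in place of phenyl on an aromatic carbon, the same kind of change as that from compound 1 to compound 2; the surroundings are described differently only in that the ring atom bearing the group is named as bearing a 3,4-dihydroxy-5-(hydroxymethyl)oxolan-2-yl group in one case and a group of 9 heavy atoms in the other. Since every value shown sits at the limit (the limit of > 20000 nM in this assay, at which 3 of the 3 values shown sit), the step from compound 3 to compound 4 is expected to be small or unreadable, estimated as a number no higher from compound 3 to compound 4 (the limit leaves the size open) beside the earlier step that the two limits leave unreadable from compound 1 to compound 2. Compound 4 is accordingly expected to give 20000 nM, most probably again reported as a limit.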

Compound 4, half-maximal inhibitory concentration: > 20000 nM
Compound 4 was reported as a limit; the forecaster's own chance of this, stated with the estimate: 85%; the middle value sits exactly at the limit.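

In this assay compound 4 gives > 20000 nM, which is a limit and not a number. Neither the step from compound 3 to compound 4 nor the step from compound 2 to compound 4 can be read: the limit of > 20000 nM in this assay, at which 4 of the 4 values shown sit.

The compounds shown leave open whether thiophen-2-yl in place of phenyl, or amino in place of methoxy, changes inhibition in this assay at all.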